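Ethoxy, butoxy and hydroxy on the ethyl chain

The source may hold more compounds than are shown below. What is called first, only, known or untested is meant among the compounds shown, and "the series" means these compounds.

Measured so far:
compound 1 `CCOCCn1c(N2CCN(C)CC2)nc2ccccc21` — 10 nM
compound 2 `CCCCOCCn1c(N2CCN(C)CC2)nc2ccccc21` — 38 nM

In a functional assay on ileum for inhibition of histamine H1 receptor (Cavia porcellus) (a lower number here means a stronger inhibitor, a higher number a weaker inhibitor), compound 2 gives the highest of the two numbers; its nearest neighbour is compound 1 with 10 nM. Compound 3 `CN1CCN(c2nc3ccccc3n2CCO)CC1` is not yet measured. It differs from compound 2 by hydrogen in place of butyl on an oxygen on a saturated carbon. Going by the values given here, the one step that bears on this is a 3.8-fold higher number from compound 1 to compound 2 (0.58 log units; beyond the scatter), where a longer chain on the oxygen went with a weaker inhibitor. Removing the chain entirely goes the other way, so compound 3 is expected to be somewhat stronger than compound 2, about a 3.2-fold lower number from compound 2 to compound 3 (0.50 log units; beyond the scatter), though the data do not reach a bare hydroxy. For compound 3 the estimate is 12 nM, within 3 nM to 50 nM.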

Compound 3, half-maximal inhibitory concentration: 410 nM
For compound 3 the middle estimate is 34-fold (1.53 log units) below the measured one; the measured number lies above the stated range.
By their numbers in this assay, from the lowest: compound 1; then compound 2; then compound 3.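

In this assay the group on the oxygen follows no single trend with chain size across these three compounds: removing butyl costs far more than lengthening ethyl to butyl did, giving an 11-fold higher number from compound 2 to compound 3 (1.03 log units; beyond the scatter). Against the ethoxy compound the loss is larger still, at a 41-fold higher number from compound 1 to compound 3 (1.61 log units; beyond the scatter). Any alkyl group shown on this oxygen therefore outperforms the free hydroxy, with ethyl giving the lowest number.

On these data alone, whether methoxy or propoxy would match ethoxy, and how an amine would read in place of the oxygen, stays open. No data here bear on why the hydroxy compound falls so far.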